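The compounds below may be only part of what the source reports. "The series", "measured", "known", "first", "only" and "open" are said of these compounds alone.

Measured in a functional assay on L1210 cells (Mus musculus) for cytotoxicity; a lower number here means a stronger inhibitor, a higher number a weaker inhibitor:
- compound 1 `COc1ccc(NC(=O)/C=C/C(=O)N2C/C(=C\c3ccc([N+](=O)[O-])cc3)C(=O)/C(=C/c3ccc([N+](=O)[O-])cc3)C2)cc1`: 2900 nM
- compound 2 `O=C(/C=C/C(=O)N1C/C(=C\c2ccccc2)C(=O)/C(=C/c2ccccc2)C1)Nc1ccc([N+](=O)[O-])cc1`: 40000 nM

Compound 2 holds the higher of the two numbers, and its gap to compound 1 lies beyond the scatter. Compound 3 `Cc1ccc(NC(=O)/C=C/C(=O)N2C/C(=C\c3ccccc3)C(=O)/C(=C/c3ccccc3)C2)cc1C` has 3,4-dimethylphenyl in place of 4-nitrophenyl on an amide-type nitrogen. Within the data shown here, no measured pair shows this change, so the expectation is loose. A small move toward a lower number in this assay is expected because compound 2 sits at 40000 nM, the top of the measured values. The estimated step is a 2.2-fold lower number from compound 2 to compound 3 (0.35 log units; beyond the scatter), close to the scatter. For compound 3 the estimate is 18000 nM, with an expected range of 5000 nM to 60000 nM.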

Compound 3, half-maximal inhibitory concentration: 31000 nM
Compound 3: middle estimate off by 1.7-fold (0.24 log units), on the low side; the measured number falls inside the stated range.
By their numbers in this assay, from the lowest: compound 1; then compounds 3 and 2 (each within the scatter of the next).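

In this assay, among these compounds, the exchange of 4-nitrophenyl for 3,4-dimethylphenyl on the amide-type nitrogen gives a 1.3-fold lower number from compound 2 to compound 3 (0.11 log units; within the scatter) and offers the first direct reading at this position. The hydrogen-bond acceptors of 4-nitrophenyl are absent from 3,4-dimethylphenyl, yet the two compounds are not separated in this read-out. No measurement on hand bears on this result.

Open, on these data alone, is whether an amine or a carboxylic acid on this phenyl ring would give a step beyond the scatter in this assay. Also open, as far as these compounds go, is whether the same exchange reads alike on the core of compound 1.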